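Removing one chloro from the trichlorophenyl group of compound 2

The source may hold more compounds than are shown below. What is called first, only, known or untested is meant among the compounds shown, and "the series" means these compounds.

Measured compounds:
compound 1, `CNC(=O)c1cnc(N)c(-c2cc(Cl)cc(Cl)c2Cl)c1`, 24000 nM
compound 2, `Cn1nccc1C(=O)Nc1ccc(-c2cc(Cl)cc(Cl)c2Cl)c(N)n1`, 750 nM
compound 3, `Cc1nocc1C(=O)Nc1ccc(-c2cc(Cl)cc(Cl)c2Cl)c(N)n1`, 670 nM

The three numbers come from an assay on HEK293 cells for inhibition of sodium channel protein type 10 subunit alpha (Homo sapiens), read by fluorescence; a higher number here means a weaker inhibitor, a lower number a stronger inhibitor. Compound 2 stands second highest of the three: compound 3 lies nearest, the step of a 1.1-fold lower number from compound 2 to compound 3 (0.05 log units; within the scatter) being within the scatter, while compound 1 lies furthest, with a far higher number than compound 2.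

Compound 4, `Cn1nccc1C(=O)Nc1ccc(-c2cc(Cl)ccc2Cl)c(N)n1`, differs from compound 2 in one place: hydrogen in place of chloro on an aromatic carbon. Among the measured compounds shown here, none of the measured steps bears directly on this change. The step from compound 2 to compound 3 swaps the heterocycle on the carbonyl carbon and leaves the trichlorophenyl group untouched; the gap between compound 1 and compound 2 involves a different amide arrangement altogether. The data therefore give no measured guide to what losing a chloro from this ring does in this assay.

For the measured compounds named here, with no anchoring step, a modest weakening is expected for compound 4, of about a 2.0-fold higher number from compound 2 to compound 4 (0.30 log units; within the scatter), with wide uncertainty on either side. Compound 4 is accordingly estimated at 1500 nM, within a range of 500 nM to 5000 nM.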

Compound 4, half-maximal inhibitory concentration: 920 nM
The estimate for compound 4 lay 1.6-fold (0.21 log units) above the measured number; the measured number falls inside the stated range.
By their numbers in this assay, from the lowest: compounds 3, 2 and 4 (each within the scatter of the next); then compound 1.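

In this assay, the chloro that stands ortho to a chloro group, meta to a chloro group and meta to a large group can be replaced by hydrogen with the result staying within the scatter: the step is a 1.2-fold higher number from compound 2 to compound 4 (0.09 log units; within the scatter). Among the compounds shown here, this is the first measured step on the trichlorophenyl group itself, since the earlier step, a 1.1-fold lower number from compound 2 to compound 3 (0.05 log units; within the scatter), changed only the heterocycle on the carbonyl carbon, so for this pair the chloro at this place is not needed to keep the number in the range of compound 2. Nothing at hand explains why the number holds when this chloro leaves, and no measurement of any property of these compounds bears on it.

The compounds shown leave open whether a fluoro, methyl or methoxy group in this same place would also stay within the scatter of compound 2, or whether such a group would move the number beyond it. They also leave open whether hydrogen in this place would give the same result with the 3-methyl-1,2-oxazol-4-yl group of compound 3, and what losing either of the two remaining chloro groups would do.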